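This account rests on a few compounds, and the source may have more. Where it says the series, first, only, none or still open, it means among the compounds named here.

Compound 2 `CCn1c(-c2cnc(C)nc2)nc2c(O[C@H]3CCN(C(=O)C4CC4)C3)ncnc21` is the reference point here. In an ADME assay on LLC-PK1 cells (Sus scrofa) for permeability (on this read-out higher numbers stand for higher permeability and lower numbers for lower permeability), compound 2 gives 28 10^-6 cm/s, the highest of the three numbers recorded, although the gap to compound 3 `CCC(=O)N1CC[C@H](Nc2ncnc3c2nc(-c2cnc(C)nc2)n3CC)C1`, which in this assay gives 21 10^-6 cm/s, is within the scatter; only compound 1 `CCn1c(-c2cnc(C)nc2)nc2c(N[C@H]3CCN(C(=O)N4CC(OC)C4)C3)ncnc21`, which in this assay gives 10 10^-6 cm/s, lies beyond it. Compound 4 `CCn1c(-c2cnc(C)nc2)nc2c(O[C@H]3CCN(C(=O)[C@H]4C[C@@H](OC)C4)C3)ncnc21` differs from compound 2 by 3-methoxycyclobutyl in place of cyclopropyl on a carbonyl carbon. Within the data shown here, no measured pair carries exactly this change. Among the measured compounds shown here, the one step at the same place is a 2.1-fold higher number from compound 1 to compound 3 (0.32 log units; beyond the scatter), in which a methoxy-bearing small ring on the carbonyl carbon was exchanged for a plain alkyl group and the number rose modestly. The change to compound 4 runs the opposite way, taking a plain carbocycle to a methoxy-bearing one, so a modest drop in this assay is expected, not a large one. Compound 4 is therefore estimated at 17 10^-6 cm/s, with a range from 9 10^-6 cm/s to 30 10^-6 cm/s. The expected step of a 1.6-fold lower number from compound 2 to compound 4 (0.22 log units; within the scatter) is modest and downward.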

Compound 4, apparent permeability: 18 10^-6 cm/s
Beside the measured number, compound 4's estimate is 1.1-fold (0.02 log units) below it; measured number inside the range.
By their numbers in this assay, from the lowest: compounds 1, 4, 3 and 2 (each within the scatter of the next, the first and the last beyond it).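

In this assay, the exchange of cyclopropyl for 3-methoxycyclobutyl on the carbonyl carbon gives a 1.6-fold lower number from compound 2 to compound 4 (0.19 log units; within the scatter), so at this position a group with more heavy atoms and one hydrogen-bond acceptor leaves a step that cannot be told from repeat scatter. Among these compounds, the only earlier step at this place, a 2.1-fold higher number from compound 1 to compound 3 (0.32 log units; beyond the scatter), lay beyond the scatter, whereas this new step, in the series with the oxygen-linked core, does not. Nothing at hand explains either step.

The compounds shown leave open whether ring size or the methoxy accounts for what little separates compound 2 and compound 4, which a plain cyclobutyl on the same carbonyl carbon would address. They also leave open how an amine in place of the methoxy, or the other stereoisomer of the 3-methoxycyclobutyl group, would read out.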